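Methylating the Ring Nitrogen of a Biphenyl Ester

The compounds below may be only part of what the source reports. "The series", "measured", "known", "first", "only" and "open" are said of these compounds alone.

Compound 2, `O=C(OCC1CCCNC1)c1ccccc1-c1ccccc1`, gives 8130 nM in an in vitro functional assay on HEK ts201 cells for antagonist activity at Neuronal acetylcholine receptor; alpha3/beta4 (Homo sapiens), read by fluorescence and calcium flux; a higher number here means a weaker inhibitor, a lower number a stronger inhibitor.
Compound 1, `O=C(OCC1CCCN(CCCc2ccccc2)C1)c1ccccc1-c1ccccc1`, gives 100000000 nM; > 100000 nM (2 entries) in this assay.

Going by the values given here, compound 2 therefore stands as the one compound with a definite number in this assay. Compound 3, `CN1CCCC(COC(=O)c2ccccc2-c2ccccc2)C1`, differs from it by methyl in place of hydrogen on an amine nitrogen in a ring. Among the compounds with values here, no measured pair shows what this change does, so the expectation for compound 3 rests on the small size of the added group alone: a modest weakening, or none beyond the usual scatter. Compound 3 is estimated at 12000 nM, with a range from 3000 nM to 45000 nM. That estimate corresponds to an expected step of a 1.5-fold higher number from compound 2 to compound 3 (0.17 log units; within the scatter).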

Compound 3, half-maximal inhibitory concentration: 4790 nM
Beside the measured number, compound 3's estimate is 2.5-fold (0.40 log units) above it, within the range that was stated.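

Putting methyl in place of hydrogen on the amine nitrogen in the ring gives a 1.7-fold lower number from compound 2 to compound 3 (0.23 log units; within the scatter), so the two compounds cannot be told apart in this assay. This shows that the ring nitrogen can carry one small group and still give a definite number, which compound 1, with its larger group on the same nitrogen, did not show. No measurement shown gives a reason for this outcome. From the compounds shown here alone, whether an ethyl group, a propyl chain or an acetyl group on this nitrogen would also give a definite number remains open.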